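Working notes: furan-to-nitrotolyl swap at the benzylamino position

A few compounds are considered here, and "the series" means these few. Any claim that something is new, unique, unknown or untested is made for them only; others in the source may bear on it.

Measured compounds in an assay on isolated protein for binding affinity to Equilibrative nucleoside transporter 1 (Homo sapiens); a lower number here means a stronger inhibitor, a higher number a weaker inhibitor:
- compound 1 `OC[C@H]1O[C@@H](n2cnc3c(NCc4ccco4)ncnc32)[C@H](O)[C@@H]1O`: 36300 nM
- compound 2 `OC[C@H]1O[C@@H](n2cnc3c(OCc4ccccc4)ncnc32)[C@H](O)[C@@H]1O`: 2090 nM
- compound 3 `Cc1cccc(CSc2ncnc3c2ncn3[C@@H]2O[C@H](CO)[C@@H](O)[C@H]2O)c1`: 12000 nM

Compound 1 stands with the highest number of the three, that is the weakest inhibition in this set; its nearest neighbour is compound 3 and its furthest is compound 2. Both measured steps from it lower the number: a 17-fold lower number from compound 1 to compound 2 (1.24 log units; beyond the scatter), and a 3.0-fold lower number from compound 1 to compound 3 (0.48 log units; beyond the scatter). The remaining step, a 5.7-fold higher number from compound 2 to compound 3 (0.76 log units; beyond the scatter), separates the two alternatives.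

Compound 4 `Cc1ccc(CNc2ncnc3c2ncn3[C@@H]2O[C@H](CO)[C@@H](O)[C@H]2O)cc1[N+](=O)[O-]` differs from compound 1 in one place: 4-methyl-3-nitrophenyl in place of furan-2-yl on a saturated chain carbon bound to a nitrogen on an aromatic ring. Among the compounds with values here, the amine linker of compound 1 is kept, so no measured step matches this change directly. The steps from compound 1 to compound 2 and from compound 1 to compound 3 each exchange the linker together with the ring, and both end in six-membered carbon rings with a lower number. That is indirect support that a carbon-only ring in place of the furan-2-yl ring is not harmful, while the sulfur-linked (3-methylbenzyl) of compound 3 tempers the gain. A modest lowering in this assay is therefore expected for compound 4, not a large one: the estimate for compound 4 is 12000 nM, with a range from 3500 nM to 40000 nM, which corresponds to an expected step of a 3.0-fold lower number from compound 1 to compound 4 (0.48 log units; beyond the scatter).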

Compound 4, half-maximal inhibitory concentration: 1170 nM
Compound 4: the middle estimate sits 10-fold (1.01 log units) above what was measured, and the stated range ends above it.
By their numbers in this assay, from the lowest: compounds 4 and 2 (each within the scatter of the next); then compound 3; then compound 1.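

With the amine linker kept, the change of furan-2-yl to 4-methyl-3-nitrophenyl on the saturated chain carbon bound to a nitrogen on an aromatic ring gives, in this assay, a 31-fold lower number from compound 1 to compound 4 (1.49 log units; beyond the scatter), a large step. Within the data shown here, the earlier steps from compound 1 exchanged the linker together with the ring, so this is the first step to change the ring and its substituents with the linker held constant, and it shows that a large lowering of the number does not require leaving the amine linker. Nothing available on this series bears on why the larger, carbon-only ring with its nitro and methyl substituents gives this step.

The contributions of the six-membered ring, the methyl group and the nitro group remain unseparated; a plain phenyl on the same amine linker, or a nitrile or carboxylic acid in place of the nitro group, would help divide them. Also open, as far as these compounds go, is whether the 4-methyl-3-nitrophenyl group would give a comparable lowering on the oxygen or sulfur linker, where only unnitrated benzyl groups appear so far.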